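This account rests on a few compounds, and the source may have more. Where it says the series, first, only, none or still open, it means among the compounds named here.

Measured compounds:
- Compound 1, `Cc1ccc(OCc2cn(C(c3ccc(C#N)cc3)c3ccc(C#N)cc3)nn2)cc1`: 11000 nM
- Compound 2, `c1ccc(C(c2ccccc2)n2ccnn2)cc1`: 4580 nM

Both compounds were tested in an assay on isolated protein for inhibition of Aromatase (Homo sapiens), read by fluorescence and colorimetric assay, with a stated time of 30 min; a higher number here means a weaker inhibitor, a lower number a stronger inhibitor. Compound 2 gives 4580 nM, the lower of the two numbers; compound 1 gives 11000 nM, a gap that lies beyond the usual scatter of this assay, so compound 2 reads as the stronger inhibitor of the pair.

Compound 3, `CCCCCCCc1cn(C(c2ccccc2)c2ccccc2)nn1`, has not yet been measured. It keeps the whole of compound 2 and differs in one place: heptyl in place of hydrogen on an aromatic carbon. The change sits on an aromatic carbon of a five-membered aromatic ring with 3 nitrogen, the ring that also carries the large group in compound 2.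

Among the compounds with values here, no pair of measured compounds shows what such a chain does here, so the expectation rests on little. Compound 1 also carries a group on that ring carbon and gives 11000 nM, a weaker result than compound 2, but it differs in several other places as well. The step from compound 2 to compound 3 is therefore expected to be small, a 1.2-fold higher number from compound 2 to compound 3 (0.08 log units; within the scatter), and could fall in either direction or within the scatter. Compound 3 is estimated at 5500 nM, with a range from 1500 nM to 20000 nM.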

Compound 3, half-maximal inhibitory concentration: 19400 nM
For compound 3 the middle estimate is 3.5-fold (0.55 log units) below the measured one; measured number inside the range.
By their numbers in this assay, from the lowest: compound 2; then compounds 1 and 3 (each within the scatter of the next).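

In this assay, heptyl in place of hydrogen on an aromatic carbon of the five-membered aromatic ring with 3 nitrogen brings a 4.2-fold higher number from compound 2 to compound 3 (0.63 log units; beyond the scatter) and so marks compound 3 as the weaker inhibitor. Within the data shown here, this is the first clean reading of this position, since compound 1 also carries a group on that ring carbon but differs from compound 2 in several other places and could not isolate the effect of that one change. For this single pair, the plain hydrogen gives the stronger inhibitor, although the modest size of the step shows that the long chain lowers inhibition without abolishing it, and nothing shown gives a reason for this change.

One chain at one position cannot show how the number depends on chain length, so a methyl group, a shorter chain or a longer chain could fall on either side of heptyl. Going by these compounds, it also remains open whether a chain ending in an amine or a carboxylic acid, or a phenyl ring on the same carbon, would behave like heptyl or give a different result.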